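A Carbonyl Enters a Series Sitting at Its Limit

The source may report more compounds than this note shows. Statements on the series, on what has been measured and on what is new or still open speak of the compounds shown alone.

Compound 1 (`Cc1ccccc1NNC(=O)c1ccc(NS(=O)(=O)c2cnc(O)nc2O)cc1`) gives > 20000 nM in a functional assay on SGC-7901 cells (Homo sapiens) for antiproliferative activity, read by MTT assay, with a stated time of 24 h (on this read-out lower numbers stand for stronger inhibition and higher numbers for weaker inhibition), as a limit of the assay, not a number. Compound 2 (`O=C(NNc1ccc(F)cc1)c1ccccc1NS(=O)(=O)c1cnc(O)nc1O`) gives > 20000 nM in this assay as a limit too. Compound 3 (`Cc1ccc(C(=O)NNC(=O)c2ccc(NS(=O)(=O)c3cnc(O)nc3O)cc2)cc1`) carries (4-methylphenyl)carbonyl in place of 2-methylphenyl on an amine nitrogen. For the measured compounds named here, with no measured step to size this change, the expected move in this assay is small and of no firm direction, and a number no higher from compound 1 to compound 3 (the limit leaves the size open) is only an estimate. Compound 3 is expected at 20000 nM (estimated range 6000 nM to 60000 nM).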

Compound 3, half-maximal inhibitory concentration: > 20000 nM
Compound 3 gave a limit, no number; the forecaster's own chance of this, stated with the estimate: 60%; the middle value sits exactly at the limit.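

Compound 1 and compound 3 both sit at a limit, so no step can be read between them: the limit of > 20000 nM in this assay, at which 3 of the 3 values shown sit.

The compounds shown leave open whether (4-methylphenyl)carbonyl in place of 2-methylphenyl changes anything in this assay.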